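Methyl to tert-Butyl on a Shared Core

The compounds below may be only part of what the source reports. "The series", "measured", "known", "first", "only" and "open" are said of these compounds alone.

Three compounds have so far been measured in a physicochemical assay for lipophilicity, in phosphate buffer, measured as octanol-water partition, at pH 7.6; a higher number here means a more lipophilic compound, a lower number a more polar compound:
compound 1 `CCCCCCCCc1noc(/C=N/O)n1` gives 3;
compound 2 `O/N=C/c1nc(-c2cccs2)no1` gives 2.38;
compound 3 `Cc1noc(/C=N/O)n1` gives 0.47.

Compound 3 stands lowest of the three numbers. Compound 2 lies nearest to it, still beyond the scatter, and compound 1 lies furthest above it. Compound 4 `CC(C)(C)c1noc(/C=N/O)n1` differs from compound 3 by tert-butyl in place of methyl on an aromatic carbon. Among the compounds with values here, no pair of measured compounds shows this change, so the reader has no measured step to lean on. The writer expects the step of a number 1.33 log units higher from compound 3 to compound 4 (beyond the scatter) in this assay to be upward and clearly beyond the scatter. On that footing compound 4 is estimated at 1.8, with a range from 1.3 to 2.3.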

Compound 4, distribution coefficient: 2.03
Estimate against measurement, compound 4: 0.23 log units below; measured number inside the range.
By their numbers in this assay, from the lowest: compound 3; then compound 4; then compound 2; then compound 1.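

In this assay, tert-butyl in place of methyl on an aromatic carbon gives the only step shown at this position, a number 1.56 log units higher from compound 3 to compound 4 (beyond the scatter), which is large. The position thus responds to this change, although compound 4 at 2.03 remains under compound 1 at 3, which carries octyl at the same place. Nothing available bears on why the step has this size.

The compounds shown leave open how an amine or a carboxylic acid at this position would read, and whether an unbranched butyl chain would match tert-butyl.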